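A few compounds are considered here, and "the series" means these few. Any claim that something is new, unique, unknown or untested is made for them only; others in the source may bear on it.

- compound 1 `COC(=O)CCCCCCCCCCCCCC/C=C1\CC(CO)(COC(=O)C(C)(C)C)OC1=O`: 7.8 ug/mL
- compound 2 `CCCCCOCCCCCCC/C=C1\CC(CO)(COC(=O)C(C)(C)C)OC1=O`: 2.99 ug/mL
- compound 3 `CC(C)(C)C(=O)OCC1(CO)C/C(=C/CCCCCCCCCCCCCCC=O)C(=O)O1`: > 10 ug/mL

These three compounds share a core and differ in the long chain attached to it. In a functional assay on SK-MEL-5 cells (Homo sapiens) for antiproliferative activity (a lower number here means a stronger inhibitor of growth, a higher number a weaker inhibitor of growth), compound 1 gives 7.8 ug/mL, the higher of the two actual numbers. Compound 3 gives > 10 ug/mL, which is a limit and not a number, so it cannot be ranked exactly.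

The next compound, compound 4 `CC(C)(C)C(=O)OCCCCCCCCCCCCCCC/C=C1\CC(CO)(COC(=O)C(C)(C)C)OC1=O`, changes only the far end of the chain of compound 1: (((tert-butyl)carbonyl)oxy)methyl in place of methoxycarbonyl on a saturated chain carbon, ten or more bonds along the chain from a double-bonded chain carbon. In words, (((tert-butyl)carbonyl)oxy)methyl stands in place of methoxycarbonyl.

For the measured compounds named here, only one measured step bears on this. It is a 2.6-fold lower number from compound 1 to compound 2 (0.42 log units; beyond the scatter), where pentyloxy replaces 7-(methoxycarbonyl)heptyl and the ester end is lost altogether. Even that larger edit moved this assay only modestly. Compound 4 keeps a carbonyl-bearing group at the chain end, so a smaller effect seems likely, with no step beyond the scatter expected. The expected change is a 1.1-fold lower number from compound 1 to compound 4 (0.05 log units; within the scatter). A limit result remains possible, given (the limit of > 10 ug/mL in this assay, at which 1 of the 3 values shown sits). For compound 4 the estimated value is 7 ug/mL, with an expected range of 3 ug/mL to 16 ug/mL.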

Compound 4, concentration for 50% growth inhibition: 3.46 ug/mL
The estimate for compound 4 lay 2.0-fold (0.31 log units) above the measured number; measured number inside the range.
By their numbers in this assay, from the lowest: compounds 2 and 4 (each within the scatter of the next); then compound 1. At a limit, above all of these: compound 3.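

In this assay, putting (((tert-butyl)carbonyl)oxy)methyl in place of methoxycarbonyl gives a 2.3-fold lower number from compound 1 to compound 4 (0.35 log units; beyond the scatter), so an edit confined to the far end of the chain is enough to move the number beyond the scatter. The earlier step replaced a long stretch of the chain together with its end, so it could not show that the end alone counts. The two groups that trade places here have the same counts of hydrogen-bond donors and acceptors and no net charge, while the entering group has more heavy atoms, all of the extra ones carbon, so a change in those donor and acceptor counts is not needed to shift this number.

This single step cannot separate the added carbon atoms from the altered ester link, as both change together in compound 4. Also open, from the compounds shown here alone, is how this assay would respond to a carboxylic acid or a primary amine at the same chain end, or to a shorter chain carrying the same (((tert-butyl)carbonyl)oxy)methyl group.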